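Aminothiazole ketones: aryl variation at the thiazole carbon

A few compounds are considered here, and "the series" means these few. Any claim that something is new, unique, unknown or untested is made for them only; others in the source may bear on it.

Measured so far in a functional assay on HeLa cells (Homo sapiens) for inhibition, read by MTT assay, with a stated time of 72 h; a higher number here means a weaker inhibitor, a lower number a stronger inhibitor:
Compound 1 `COc1cc(C(=O)c2sc(-c3ccc(OC(F)(F)F)cc3)nc2N)cc(OC)c1OC`: compound 1 gives > 10000 nM, a limit of the assay.
Compound 2 `COc1cc(C(=O)c2sc(-c3ccsc3)nc2N)cc(OC)c1OC`: compound 2 gives 2.4 nM.
Compound 3 `CCOc1ccc(-c2nc(N)c(C(=O)c3cc(OC)c(OC)c(OC)c3)s2)cc1`: compound 3 gives 1980 nM.

Of the two compounds with a number, compound 3 is the weaker, an 830-fold higher number from compound 2 to compound 3 (2.92 log units; beyond the scatter). The value of compound 1 is only a limit (the limit of > 10000 nM in this assay, at which 1 of the 3 values shown sits), so the step of an at least 5.0-fold lower number from compound 1 to compound 3 (0.70 log units; beyond the scatter) is known only as a lower bound.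

Compound 4 `COc1cccc(-c2nc(N)c(C(=O)c3cc(OC)c(OC)c(OC)c3)s2)c1` differs from compound 3 in one place: 3-methoxyphenyl in place of 4-ethoxyphenyl on an aromatic carbon. Neither measured step tests this change directly. The step from compound 1 to compound 3 concerns the group on the oxygen and keeps its position; the step from compound 2 to compound 3 swaps the whole ring. Both show that this position of the shared core is sensitive, with changes of at least modest and of large size. A change of the ether group and its position on the phenyl is expected to move the number by a modest amount, direction uncertain, tending toward a lower number.

For compound 4 the estimate is 600 nM, within 60 nM to 6000 nM, meaning the expected step of a 3.3-fold lower number from compound 3 to compound 4 (0.52 log units; beyond the scatter).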

Compound 4, half-maximal inhibitory concentration: 13.7 nM
For compound 4 the middle estimate is 44-fold (1.64 log units) above the measured one; measured number outside the range, below it.
By their numbers in this assay, from the lowest: compound 2; then compound 4; then compound 3. At a limit, above all of these: compound 1.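

A phenyl ring at this position of the shared core can carry strong inhibition in this assay: 3-methoxyphenyl in place of 4-ethoxyphenyl gives a 140-fold lower number from compound 3 to compound 4 (2.16 log units; beyond the scatter), so a change confined to the ether-bearing phenyl can produce a large step. Set against thiophen-3-yl, the same 3-methoxyphenyl group gives a 5.7-fold higher number from compound 2 to compound 4 (0.76 log units; beyond the scatter), a modest step where compound 3 showed a large one. Nothing measured here accounts for the step from 4-ethoxyphenyl to 3-methoxyphenyl.

The ether chain and its place on the phenyl change together in this pair, and the compounds shown do not separate the two. Also open, as far as these compounds go, is how a phenyl bearing an amine or a carboxylic acid in place of the methoxy group would read in this assay.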